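Bulk on the amide-type nitrogen: ethyl to tert-butyl

The source may report more compounds than this note shows. Statements on the series, on what has been measured and on what is new or still open speak of the compounds shown alone.

Two compounds of the series have numbers in a functional assay on IMR-90 cells for antagonist activity at B1 bradykinin receptor (Homo sapiens), read by calcium flux; a lower number here means a stronger inhibitor, a higher number a weaker inhibitor. Compound 1 `Cc1nc(-c2c(F)cc(Cl)cc2-c2cnc([C@@H](C)NC(=O)N(C)O)c(F)c2)no1` gives 1.2 nM in this assay. Compound 2 `CCN(O)C(=O)NCc1ncc(-c2cc(Cl)cc(F)c2-c2nnn(C)n2)cc1F` gives 4.6 nM, the higher of the two numbers; the gap to compound 1 lies beyond the scatter, so compound 2 is the weaker of the pair.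

Compound 3 `Cn1nnc(-c2c(F)cc(Cl)cc2-c2cnc(CNC(=O)N(O)C(C)(C)C)c(F)c2)n1` has not been measured. It differs from compound 2 in one place: tert-butyl in place of ethyl on an amide-type nitrogen, that is, tert-butyl in place of ethyl on the amide-type nitrogen whose other neighbours are a carbonyl carbon and an oxygen. For the measured compounds named here, no measured pair shows this change, so its effect is unknown from the series itself. The step from compound 2 to compound 3 is expected to be small in this assay, as a 1.0-fold lower number from compound 2 to compound 3 (0.01 log units; within the scatter), with no clear direction beyond the scatter. Compound 3 is therefore estimated at 4.5 nM, within a range of 1.5 nM to 14 nM.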

Compound 3, half-maximal inhibitory concentration: 1.4 nM
The estimate for compound 3 lay 3.2-fold (0.51 log units) above the measured number, outside the stated range (below it).
By their numbers in this assay, from the lowest: compounds 1 and 3 (each within the scatter of the next); then compound 2.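

For the compounds shown here, on the amide-type nitrogen whose other neighbours are a carbonyl carbon and an oxygen, tert-butyl in place of ethyl gives in this assay a 3.3-fold lower number from compound 2 to compound 3 (0.52 log units; beyond the scatter) as a modest step, the first reading of any change at this place. The nitrogen therefore carries tert-butyl, with 4 heavy atoms against 2 for ethyl, without any loss in this assay and with a gain beyond the scatter. Nothing available bears on what lies behind this step.

Between and beyond these two groups, isopropyl, cyclopropyl and a longer chain such as n-butyl remain open, as does a methoxy group in place of the hydroxy on the same nitrogen. Also open, on these data alone, is whether tert-butyl gives a step of the same direction on the core of compound 1, which carries methyl on this nitrogen.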